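The source may report more compounds than this note shows. Statements on the series, on what has been measured and on what is new or still open speak of the compounds shown alone.

Measured so far:
compound 1 `COc1ncccc1C(=O)NCCC1CCN(S(=O)(=O)NC(=O)NC2CCCCC2)CC1` gives 33%
compound 2 `COc1ncccc1C(=O)NCCC1CCN(S(=O)(=O)NC(=O)NC[C@@H]2C[C@@H]3CC[C@@H]2O3)CC1` gives 34%

Within the data shown here, in a functional assay on the whole organism (blood) with Rattus norvegicus as the target, with stated times of 24 h and 1 h, at a dose of 5 mg/kg by the intraperitoneal route (a lower number here means a weaker effect, a higher number a stronger effect of the compound at the dose given), compound 2 sits within the usual scatter of compound 1, the only other measurement. Compound 3 `COc1ncccc1C(=O)NCCC1CCN(S(=O)(=O)NC(=O)NC[C@@H]2C[C@@H]3CC[C@@H]2C3)CC1` differs from compound 2 by a group of 7 heavy atoms (7 carbon; 2 five-membered non-aromatic rings of carbon only) in place of a group of 7 heavy atoms (6 carbon, 1 oxygen; 2 five-membered non-aromatic rings with 1 hetero atom each), on a saturated chain carbon bound to an amide-type nitrogen. Among the measured compounds shown here, the one measured step that touches this region, a number 1 percentage points higher from compound 1 to compound 2 (within the scatter), changed the group on the amide-type nitrogen and stayed within the scatter, so a change of one ring atom in the same region is expected to move the number little. The expected step is a number 2 percentage points lower from compound 2 to compound 3 (within the scatter). Compound 3 is therefore estimated at 32%, in a range from 18% to 46%.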

Compound 3, a percentage reported as activity, at one dose (the size of the read-out at that dose, not a potency): 35%
For compound 3 the middle estimate is 3 percentage points below the measured one; low and high end bracket the measured number.
By their numbers in this assay, from the lowest: compounds 1, 2 and 3 (each within the scatter of the next).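

In this assay, putting carbon in place of the ring oxygen on the saturated chain carbon bound to an amide-type nitrogen gives a number 1 percentage points higher from compound 2 to compound 3 (within the scatter) and so shows that this single hydrogen-bond acceptor can go without a change beyond the scatter. Replacing the six-membered carbon ring on the amide-type nitrogen with the all-carbon group of 2 five-membered rings gives a number 2 percentage points higher from compound 1 to compound 3 (within the scatter) and likewise stays within the scatter. No supporting measurement bears on this result. As far as these compounds go, whether an amine or a carboxylic acid at this place would move the number beyond the scatter remains open.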